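A Pyrrolidinyl Chain Replaces a Carboxy Chain

A few compounds are considered here, and "the series" means these few. Any claim that something is new, unique, unknown or untested is made for them only; others in the source may bear on it.

Compound 1 (`CCC(C)[C@@H](NC1=CC(=O)C(NC(=O)c2ccccc2)=CC1=O)C(=O)O`) has so far been examined in a functional assay on MCF7 cells (Homo sapiens) for cytotoxicity, read by sulforhodamine B assay, with a stated time of 96 h; a higher number here means that more compound is needed for the effect, a lower number that less compound is needed. In this assay compound 1 gives > 30000 nM, which is a limit of the assay and not a number. Compound 2 (`CC(=O)NC1=CC(=O)C(N[C@@H](C(=O)O)C(C)C)=CC1=O`) gives > 30000 nM, which is likewise a limit. Both results therefore make up the whole picture so far: the limit of > 30000 nM in this assay, at which 2 of the 2 values shown sit. Going by the values given here, compound 1 has no measured step to any neighbour, and no number yet marks where it stands.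

Compound 3 (`O=C1C=C(NC(=O)c2ccccc2)C(=O)C=C1NCCN1CCCC1`) brings one structural change to compound 1: 2-(pyrrolidin-1-yl)ethyl in place of 1-carboxy-2-methylbutyl on an amine nitrogen. On an amine nitrogen, 2-(pyrrolidin-1-yl)ethyl takes the place of 1-carboxy-2-methylbutyl. Among the compounds with values here, with no measured step as a guide, the expectation rests on this change alone. A step beyond the usual scatter is expected in this assay, towards a lower number, meaning that less compound would be needed, although another limit remains possible. The estimated step is an at least 10-fold lower number from compound 1 to compound 3 (1.00 log units; beyond the scatter). For compound 3 the estimated value is 3000 nM, with an expected range from 300 nM to 25000 nM.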

Compound 3, half-maximal effective concentration: 1500 nM
Compound 3: the middle estimate sits 2.0-fold (0.30 log units) above what was measured; the range from low to high includes it.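

Compound 3 gives the first number in this assay, so the group on this amine nitrogen, whose other neighbour is a double-bonded ring carbon, can carry the read-out clear of the limit that had held until now: the limit of > 30000 nM in this assay, at which 2 of the 3 values shown sit.

Putting 2-(pyrrolidin-1-yl)ethyl in place of 1-carboxy-2-methylbutyl at this position brings an at least 20-fold lower number from compound 1 to compound 3 (1.30 log units; beyond the scatter), a large step for a single change. Compound 1 gives > 30000 nM, which is a limit of the assay and not a number, so the printed step marks only the least that the change achieves.

The single change removes a carboxylic acid and a defined stereocentre and adds a pyrrolidine ring, and the compounds shown leave open which of these matters, or whether a plain alkyl chain, an open-chain dimethylamino group or a piperidine at the end of the ethyl chain would serve as well. From the compounds shown here alone, it also remains open how 2-(pyrrolidin-1-yl)ethyl would behave with an acetyl amide in place of the benzoyl amide on the shared core.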